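The compounds below may be only part of what the source reports. "The series", "measured", "known", "first", "only" and "open" are said of these compounds alone.

Measured compounds:
compound 1, `CCOC(=O)c1cnc(C(F)(F)F)nc1NN1C(=O)C=C(C)C1=O`: 1000 nM
compound 2, `CCOC(=O)c1cnc(-c2ccc(C(F)(F)F)cc2)nc1NN1C(=O)C=C(C)C1=O`: 400 nM
compound 3, `CCOC(=O)c1cnc(-c2cc(Cl)cc(Cl)c2)nc1NN1C(=O)C=C(C)C1=O`: not yet measured

In a functional assay on Jurkat cells for inhibition of nuclear factor NF-kappa-B complex (Homo sapiens) (a higher number here means a weaker inhibitor, a lower number a stronger inhibitor), compound 1 gives 1000 nM and compound 2 gives 400 nM. Among the measured compounds shown here, compound 2 holds the lowest of the two numbers known so far; its only neighbour is compound 1, from which it is separated by a 2.5-fold lower number from compound 1 to compound 2 (0.40 log units; beyond the scatter), a modest step that replaces trifluoromethyl with 4-(trifluoromethyl)phenyl at the same position of the shared core.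

Compound 3 differs from compound 2 as follows: 3,5-dichlorophenyl in place of 4-(trifluoromethyl)phenyl on an aromatic carbon. For the measured compounds named here, the one measured step touches the same position but is of a different kind, since it sets an aromatic ring where a small group stood; the present change keeps an aromatic ring in place and alters only its substituents. Going by the values given here, no measured pair therefore speaks to the change directly. With nothing pointing either way, the expectation for compound 3 is a number close to that of compound 2, with a step of no change at the digits printed from compound 2 to compound 3 (within the scatter) that stays within the scatter. Compound 3 is estimated at 400 nM, in the range 150 nM to 1200 nM.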

Compound 3, half-maximal inhibitory concentration: 300 nM
Estimate against measurement, compound 3: 1.3-fold (0.12 log units) above; the range from low to high includes it.
By their numbers in this assay, from the lowest: compounds 3 and 2 (each within the scatter of the next); then compound 1.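

In this assay, exchanging one substituted phenyl for another on the aromatic carbon between two ring nitrogen atoms gives a 1.3-fold lower number from compound 2 to compound 3 (0.12 log units; within the scatter), so 4-(trifluoromethyl)phenyl and 3,5-dichlorophenyl cannot be told apart here, even though their substituents differ in both identity and placement on the ring. Against the small trifluoromethyl group, 3,5-dichlorophenyl gives a 3.3-fold lower number from compound 1 to compound 3 (0.52 log units; beyond the scatter), so the shift seen earlier with a 2.5-fold lower number from compound 1 to compound 2 (0.40 log units; beyond the scatter) now appears with a second substituted phenyl and is not tied to 4-(trifluoromethyl)phenyl alone, though the series still holds only these two examples. Nothing measured on these compounds offers an explanation for either the shared level of compounds 2 and 3 or their separation from compound 1.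

Still open, on these data alone, is how a phenyl with no substituents, or a phenyl carrying an amine or a carboxylic acid, would compare at this position, and so whether the substituents matter at all or the ring alone accounts for the step from trifluoromethyl. Also open, as far as these compounds go, is whether the same pattern would hold if the ethoxycarbonyl group gave way to a carboxylic acid or an amide.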